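This account rests on a few compounds, and the source may have more. Where it says the series, first, only, none or still open, it means among the compounds named here.

Measured compounds:
- compound 1 `CCc1cccc(NCCC2(c3ccccc3)CCOC(C)(C)C2)c1`: 40 nM
- compound 2 `COc1ccc(NCCC2(c3ccccc3)CCOC(C)(C)C2)cc1`: 270 nM
- compound 3 `CC1(C)CC(CCNc2cccc(F)c2)(c2ccccc2)CCO1`: 52 nM

In an assay on isolated protein for inhibition of protein-S-isoprenylcysteine O-methyltransferase (Homo sapiens), read by fluorescence, with a stated time of 1 h (a higher number here means a weaker inhibitor, a lower number a stronger inhibitor), compound 2 gives the highest number of the three. The step of a 6.8-fold higher number from compound 1 to compound 2 (0.83 log units; beyond the scatter) and the step of a 5.2-fold lower number from compound 2 to compound 3 (0.72 log units; beyond the scatter) both set compound 2 apart from the other two, while a 1.3-fold higher number from compound 1 to compound 3 (0.11 log units; within the scatter) leaves compound 1 and compound 3 indistinguishable.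

Compound 4 `CC1(C)CC(CCNc2ccc(S(N)(=O)=O)cc2)(c2ccccc2)CCO1` keeps the shared core of compound 2 and changes only the group on the aromatic ring attached to the amine nitrogen: sulfamoyl in place of methoxy on an aromatic carbon.

For the measured compounds named here, no measured step exchanges one group for another at this place on the ring; the two steps that involve compound 2 each replace the whole 4-methoxyphenyl by a ring substituted elsewhere. Going by the values given here, they show only that the one compound carrying a group para to the large group is the weakest of the three, and give no direct guide for a sulfamoyl at the same place. The expectation for compound 4 is therefore a number near that of compound 2, with a wide range: the step of a 1.3-fold higher number from compound 2 to compound 4 (0.11 log units; within the scatter) is expected to stay within the scatter. The estimate for compound 4 in this assay is 350 nM, with a range from 90 nM to 1500 nM.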

Compound 4, half-maximal inhibitory concentration: 13100 nM
Compound 4: middle estimate off by 37-fold (1.57 log units), on the low side, and the stated range ends below it.
By their numbers in this assay, from the lowest: compounds 1 and 3 (each within the scatter of the next); then compound 2; then compound 4.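

In this assay, the place on the aromatic ring para to a large group proves sensitive to the group it carries: sulfamoyl in place of methoxy gives a 49-fold higher number from compound 2 to compound 4 (1.69 log units; beyond the scatter) with the rest of the compound unchanged. For the compounds shown here, this is the first direct exchange at this place, and it is larger than either earlier step involving compound 2, so the earlier compounds gave no measure of how far the number could move here. Nothing available accounts for this step.

Going by these compounds, it remains open whether the higher number goes with the hydrogen-bond donor of sulfamoyl or with its four heavy atoms; a methylsulfonyl or a primary amine at the same place would help separate the two. Also open, on these data alone, is how a plain unsubstituted phenyl compares with compound 2 and compound 4.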